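Adding a methoxy group to compound 3

The compounds below may be only part of what the source reports. "The series", "measured", "known", "first", "only" and "open" are said of these compounds alone.

In a functional assay on B16-F10 cells (Mus musculus) for antiproliferative activity, read by MTT assay, with a stated time of 48 h (on this read-out higher numbers stand for weaker inhibition and lower numbers for stronger inhibition), compound 3 `COc1ccc(/C=C/c2cc(OC)cc(OC)c2/C=C/C(=O)c2ccccc2)cc1` gives 3.7 ug/mL. This lies within the scatter of compound 2 `COc1ccc(/C=C/c2cc(OC)cc(OC)c2/C=C/C(=O)c2cccc(OC)c2)cc1` at 4.3 ug/mL, while compound 1 `COc1ccc(/C=C/c2cc(OC)cc(OC)c2/C=C/C(=O)c2ccc(Cl)c(Cl)c2)cc1` reads 7.5 ug/mL, a modest gap beyond the scatter. Compound 4 `COc1ccc(/C=C/c2cc(OC)cc(OC)c2/C=C/C(=O)c2ccc(OC)cc2)cc1` departs from compound 3 in one place, methoxy in place of hydrogen on an aromatic carbon, para to a large group.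

For the measured compounds named here, two measured steps bear on this change. The closest is a 1.2-fold lower number from compound 2 to compound 3 (0.07 log units; within the scatter), which also concerns methoxy and hydrogen, though at another place. The largest step in the series is a 2.0-fold lower number from compound 1 to compound 3 (0.31 log units; beyond the scatter), and it only just clears the scatter. Neither step shows how a methoxy group behaves at the new place, so only a small change is anticipated, with no shift beyond the scatter and a slight lean towards a higher number. The expected change is a 1.2-fold higher number from compound 3 to compound 4 (0.07 log units; within the scatter). For compound 4 the estimated value is 4.3 ug/mL, with an expected range from 2.4 ug/mL to 7.5 ug/mL.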

Compound 4, half-maximal inhibitory concentration: 5.8 ug/mL
For compound 4 the middle estimate is 1.3-fold (0.13 log units) below the measured one; low and high end bracket the measured number.
By their numbers in this assay, from the lowest: compounds 3, 2, 4 and 1 (each within the scatter of the next, the first and the last beyond it).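

In this assay methoxy on an aromatic carbon para to a large group stays within the scatter of the unsubstituted phenyl (a 1.6-fold higher number from compound 3 to compound 4 (0.20 log units; within the scatter)), so this position accepts the group without a clear shift in either direction. Changing 3-methoxyphenyl to 4-methoxyphenyl also stays within the scatter (a 1.3-fold higher number from compound 2 to compound 4 (0.13 log units; within the scatter)), as does changing 3,4-dichlorophenyl to 4-methoxyphenyl (a 1.3-fold lower number from compound 1 to compound 4 (0.11 log units; within the scatter)), so compound 4 cannot be separated from any of the three earlier compounds, even though compound 1 and compound 3 lie beyond the scatter of each other. No supporting measurement bears on how this methoxy group acts at this position.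

From the compounds shown here alone, whether any group on this carbon can move the number beyond the scatter remains open. An amine, a carboxylic acid or a longer chain such as butoxy would test this.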